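The source may report more compounds than this note shows. Statements on the series, on what has been measured and on what is new or still open speak of the compounds shown alone.

In a functional assay on THP-1 cells (Homo sapiens) for cytotoxicity, read by MTT assay, with a stated time of 24 h (on this read-out higher numbers stand for weaker inhibition and lower numbers for stronger inhibition), compound 1 `COc1cc(/C=C2\CN(C)C/C(=C\c3cc(OC)c(OC)c(OC)c3)C2=O)cc(OC)c1` gives 720 nM, compound 2 `COc1cc(/C=C2\CN(C)C/C(=C\c3ccc(Cl)cc3)C2=O)cc(OC)c1OC` gives 7200 nM and compound 3 `COc1cc(/C=C2\CN(C)C/C(=C\c3ccc(Br)cc3)C2=O)cc(OC)c1OC` gives 5330 nM. Compound 3 thus sits level with compound 2, within the scatter, and both numbers lie above that of compound 1. Compound 4 `COc1cc(/C=C2\CN(C)C/C(=C\c3ccc(Cl)cc3Cl)C2=O)cc(OC)c1OC` carries 2,4-dichlorophenyl in place of 4-bromophenyl on a double-bonded chain carbon bound to a double-bonded ring carbon. The closest evidence is a 1.4-fold lower number from compound 2 to compound 3 (0.13 log units; within the scatter), which stays within the scatter. The larger steps, a 10-fold higher number from compound 1 to compound 2 (1.00 log units; beyond the scatter) and a 7.4-fold higher number from compound 1 to compound 3 (0.87 log units; beyond the scatter), both remove 3,5-dimethoxyphenyl, which compound 3 already lacks. Within the data shown here, no compound measured so far carries two chloro groups, so the expectation in this assay is of no shift beyond the scatter. The expected step is a 1.1-fold lower number from compound 3 to compound 4 (0.03 log units; within the scatter). Compound 4 is expected at 5000 nM, with an estimated range of 2200 nM to 11000 nM.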

Compound 4, half-maximal inhibitory concentration: 5020 nM
Compound 4: middle estimate off by 1.0-fold (0.00 log units), on the low side, and the stated range covers the measured number.
By their numbers in this assay, from the lowest: compound 1; then compounds 4, 3 and 2 (each within the scatter of the next).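

In this assay a second chloro on the ring gives a 1.4-fold lower number from compound 2 to compound 4 (0.16 log units; within the scatter) and 2,4-dichlorophenyl in place of 4-bromophenyl gives a 1.1-fold lower number from compound 3 to compound 4 (0.03 log units; within the scatter); at this position, adding a halogen or exchanging one leaves the number unmoved. The distance from the 3,5-dimethoxyphenyl of compound 1 remains, at a 7.0-fold higher number from compound 1 to compound 4 (0.84 log units; beyond the scatter). No measurement here accounts for either result. Still open, from the compounds shown here alone, is whether a single methoxy group, an amine or a carboxylic acid on this phenyl ring would bring the number back towards that of compound 1.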